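Dipropylamino in place of diethylamino: a small expected rise

The source may report more compounds than this note shows. Statements on the series, on what has been measured and on what is new or still open speak of the compounds shown alone.

Values in a functional assay on the whole organism with Mus musculus as the target; a lower number here means that less compound is needed, a higher number that more compound is needed for the effect:
- Compound 1 `NC(=O)Cn1c(-c2ccc(Cl)cc2)nc2cccnc21`: 4.1 mg/kg
- Compound 2 `CCN(CC)C(=O)Cn1c(-c2ccc(Cl)cc2)nc2cccnc21`: 16 mg/kg
- Compound 3 `CCCN(CCC)C(=O)Cn1c(-c2ccc(Cl)cc2)nc2cccnc21`: not yet measured

Of the two measured compounds, compound 2 has the higher number at 16 mg/kg, while compound 1 stands lower at 4.1 mg/kg. Compound 3 differs from compound 2 by dipropylamino in place of diethylamino on a carbonyl carbon. Among the measured compounds shown here, only one measured step bears on this change: a 3.9-fold higher number from compound 1 to compound 2 (0.59 log units; beyond the scatter). It is modest, lies beyond the scatter and falls on the same carbonyl carbon. For the measured compounds named here, one step makes a thin basis, and no measured compound shows the effect of dipropylamino itself. A small further rise in this assay is expected, possibly within the scatter. The expected step is a 1.5-fold higher number from compound 2 to compound 3 (0.18 log units; within the scatter). For compound 3 the estimate is 24 mg/kg, with an expected range of 8 mg/kg to 70 mg/kg.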

Compound 3, dose for half-maximal effect: 11 mg/kg
Compound 3: the middle estimate sits 2.2-fold (0.34 log units) above what was measured, and the stated range covers the measured number.
By their numbers in this assay, from the lowest: compound 1; then compounds 3 and 2 (each within the scatter of the next).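

In this assay, dipropylamino in place of diethylamino on a carbonyl carbon gives a 1.5-fold lower number from compound 2 to compound 3 (0.16 log units; within the scatter) and stays within the scatter, so at this position the rise seen when diethylamino replaced amino does not carry on with this further change in chain length. Dipropylamino in place of amino gives a 2.7-fold higher number from compound 1 to compound 3 (0.43 log units; beyond the scatter) and lies beyond the scatter, which leaves compound 1, with its unsubstituted amino group, apart from both dialkylamino compounds. The data available offer no explanation for either step.

The compounds shown leave open whether a methylamino group, with one chain on the nitrogen, would stand with compound 1 or with the two dialkylamino compounds. They also leave open whether a longer chain such as dibutylamino, or a ring amine such as piperidine, would stay at the same level.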